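Methoxy to ethoxy at the limit of the assay

The source may hold more compounds than are shown below. What is called first, only, known or untested is meant among the compounds shown, and "the series" means these compounds.

Measured in a functional assay on A549 cells (Homo sapiens) for cytotoxicity, read by MTT assay, with a stated time of 24 h (on this read-out lower numbers stand for stronger inhibition and higher numbers for weaker inhibition), as follows:
Compound 1 (`CC(C)c1cc2c(cc1O)[C@]13CCC[C@](C)(CO[C@H]1O)[C@@H]3CC2`): > 10000 nM
Compound 2 (`CO[C@@H]1OC[C@@]2(C)CCC[C@@]13c1cc(O)c(C(C)C)cc1CC[C@@H]23`): > 10000 nM
Compound 3 (`CO[C@H]1OC[C@@]2(C)CCC[C@@]13c1cc(O)c(C(C)C)cc1CC[C@@H]23`): > 10000 nM

Compound 2 sits at > 10000 nM as a limit of the assay, not a number. The whole set shows the limit of > 10000 nM in this assay, at which 3 of the 3 values shown sit, in place of readable numbers. Compound 4 (`CCO[C@@H]1OC[C@@]2(C)CCC[C@@]13c1cc(O)c(C(C)C)cc1CC[C@@H]23`) alters compound 2 in one place: methyl in place of hydrogen on a saturated chain carbon bound to an oxygen on a saturated carbon (methoxy to ethoxy). For the measured compounds named here, two measured steps bear on this. Going by the values given here, the nearest is a step that the two limits leave unreadable from compound 1 to compound 2 on that oxygen, and the other is a step that the two limits leave unreadable from compound 2 to compound 3 with the fact that compounds 2 and 3 differ only in the configuration as drawn as its only change. Neither gives a size or a direction. The estimate is therefore a step that the limit leaves unreadable from compound 2 to compound 4 in this assay with no direction expected and no size beyond the scatter. Compound 4 is expected at 20000 nM with a range of 10000 nM to 50000 nM and will probably be reported as a limit again.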

Compound 4, half-maximal inhibitory concentration: > 10000 nM
Compound 4: a limit, no number; the forecaster's own chance of this, stated with the estimate: 85%; the middle value does not contradict the limit.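

Compound 4, like compound 1 and compound 2, gives only a limit of the assay and not a number, so no new step can be read. The compounds shown leave open how much methoxy to ethoxy changes activity in this assay.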